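The source may hold more compounds than are shown below. What is called first, only, known or untested is meant among the compounds shown, and "the series" means these compounds.

Compound 3 `CN1CCN(c2ccc(C3=NN(S(C)(=O)=O)C(c4ccc(N(C)C)cc4)C3)cc2)CC1` stands lowest of the three measured compounds in a functional assay on HCC1806 cells (Homo sapiens) for inhibition, read by sulforhodamine B assay, tested at 10 uM (on this read-out lower numbers stand for less inhibition and higher numbers for more inhibition at the one concentration tested (going by the name of the read-out)), where compound 3 gives -18.5%. Compound 1 `CN1CCN(c2ccc(C3=NNC(c4ccc(N(C)C)cc4)C3)cc2)CC1` gives 31.2% and compound 2 `CN1CCN(c2ccc(C3=NN(C(=O)c4ccc(F)cc4)C(c4ccc(N(C)C)cc4)C3)cc2)CC1` gives 31.8%. Both steps that lead to compound 3 are large: a number 49.7 percentage points lower from compound 1 to compound 3 (beyond the scatter) and a number 50.3 percentage points lower from compound 2 to compound 3 (beyond the scatter). Compound 4 `CN1CCN(c2ccc(C3=NN(S(=O)(=O)C4CC4)C(c4ccc(N(C)C)cc4)C3)cc2)CC1` keeps the sulfonyl and differs from compound 3 only in one place: cyclopropyl in place of methyl on a sulfonyl sulfur. No measured step alters the group on the sulfonyl sulfur, so nothing shown bears directly on this change; the two large steps concern the sulfonyl itself, which compound 4 retains. The expected step is a number 3.5 percentage points higher from compound 3 to compound 4 (within the scatter), within the scatter. Compound 4 is therefore estimated to give -15%, with a range from -40% to 8%.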

Compound 4, a percentage reported as inhibition, at one concentration (the size of the read-out at that concentration, not a potency): 4.7%
For compound 4 the middle estimate is 19.7 percentage points below the measured one; the measured number falls inside the stated range.
By their numbers in this assay, from the lowest: compound 3; then compound 4; then compounds 1 and 2 (each within the scatter of the next).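

The group on the sulfonyl sulfur does matter in this assay: with cyclopropyl in place of methyl there is a number 23.2 percentage points higher from compound 3 to compound 4 (beyond the scatter) and the step is modest. Cyclopropylsulfonyl still does not reach the other two groups on the ring nitrogen, with a number 26.5 percentage points lower from compound 1 to compound 4 (beyond the scatter) and a number 27.1 percentage points lower from compound 2 to compound 4 (beyond the scatter), so only part of the drop seen with methylsulfonyl is regained. Nothing available explains why this change moves the number.

Going by these compounds, only methyl and cyclopropyl appear on the sulfonyl sulfur, so the effect of an ethyl, isopropyl or phenyl group there remains open. On these data alone, whether a longer chain or a larger ring would move the number further also remains unknown.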